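This account rests on a few compounds, and the source may have more. Where it says the series, first, only, none or still open, it means among the compounds named here.

Compound 1 `CC1=CC[C@H]2[C@H](CC[C@]2(C)O)C(C)(C)[C@@H]1CC[C@H]1[C@]2(C)CC[C@H](OC(=O)c3ccccc3)C(C)(C)O[C@H]2CC[C@@]1(C)O` carries a benzoyl ester on its shared core. Among the measured compounds shown here, in a functional assay on MCF7 cells (Homo sapiens) for antiproliferative activity, read by MTT assay, with a stated time of 72 h (a higher number here means a weaker inhibitor, a lower number a stronger inhibitor), compound 1 gives 21000 nM, the only full number among the three measured compounds. Compound 2 `CC1=CC[C@H]2[C@@H]1CC=C(C)[C@@H](CC[C@H]1[C@]3(C)CC[C@H](OC(=O)CCC(=O)O)C(C)(C)O[C@H]3CC[C@@]1(C)O)C2(C)C` reaches only a limit of the assay, > 50000 nM, in this assay. Compound 3 `CC1=CC[C@H]2[C@H](CC[C@]2(C)O)C(C)(C)[C@@H]1CC[C@H]1[C@]2(C)CC/C(=N/OCc3ccccc3)C(C)(C)O[C@H]2CC[C@@]1(C)O` likewise stops at a limit, > 50000 nM, in this assay. Compound 1 thus stands apart from the other two, given (the limit of > 50000 nM in this assay, at which 2 of the 3 values shown sit). Compound 4 `CC1=CC[C@H]2[C@H](CC[C@]2(C)O)C(C)(C)[C@@H]1CC[C@H]1[C@]2(C)CC[C@H](OC(=O)c3ccc(Cl)c(Cl)c3)C(C)(C)O[C@H]2CC[C@@]1(C)O` differs from compound 1 in a single place: 3,4-dichlorophenyl in place of phenyl on a carbonyl carbon. For the measured compounds named here, no measured pair shows what this change does here, and no step beyond the usual scatter is expected in this assay. Compound 4 is estimated at 15000 nM, between 5000 nM and 45000 nM, an expected step of a 1.4-fold lower number from compound 1 to compound 4 (0.15 log units; within the scatter).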

Compound 4, half-maximal inhibitory concentration: 11900 nM
The estimate for compound 4 lay 1.3-fold (0.10 log units) above the measured number, and the stated range covers the measured number.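

Among the compounds shown here, this is the first measured pair at this position: 3,4-dichlorophenyl in place of phenyl on a carbonyl carbon gives a 1.8-fold lower number from compound 1 to compound 4 (0.25 log units; within the scatter) in this assay. The position therefore accepts the two chlorine atoms without a step beyond the scatter, so this change neither clearly helps nor clearly harms. Compound 4 also gives a full number, as compound 1 does, rather than a limit: the limit of > 50000 nM in this assay, at which 2 of the 4 values shown sit.

On these data alone, what a single chlorine would do stays open, since the two chlorine atoms entered together. So does the effect of an amine on the aromatic ring, or of a longer chain in place of phenyl.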